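The source may hold more compounds than are shown below. What is called first, only, known or untested is meant among the compounds shown, and "the series" means these compounds.

In an ADME assay on MT4 cells (Homo sapiens) for cytotoxicity, read by MTT assay (on this read-out higher numbers stand for lower toxicity in this test and lower numbers for higher toxicity in this test), compound 1 `CN1C(=O)c2ccccc2C(C(=O)NCc2ccc(F)cc2)C1=O` gives > 250000 nM, which is a limit of the assay and not a number. Compound 2 `O=C(Nc1ccccc1)C1C(=O)N(O)C(=O)c2ccccc21` gives 106000 nM. Within the data shown here, compound 3 `O=C(Nc1cccc(F)c1)C1C(=O)N(O)C(=O)c2ccccc21` gives 64000 nM, and so stands level with compound 2, the only other compound with a number.

Next in line is compound 4 `O=C(Nc1ccc(F)cc1)C1C(=O)N(O)C(=O)c2ccccc21`, which differs from compound 3 as follows: 4-fluorophenyl in place of 3-fluorophenyl on an amide-type nitrogen. The two have the same atoms, joined differently, with 4-fluorophenyl in place of 3-fluorophenyl on an amide-type nitrogen.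

Among the measured compounds shown here, the one measured step that bears on this change is fluoro in place of hydrogen on an aromatic carbon, a 1.7-fold lower number from compound 2 to compound 3 (0.22 log units; within the scatter). For the measured compounds named here, no measured step compares the two fluorophenyl groups directly. Going by the values given here, with only that small step to go on, no change beyond the scatter is expected in this assay, and no direction is favoured.

The expected step is a 1.1-fold higher number from compound 3 to compound 4 (0.04 log units; within the scatter). For compound 4 the estimated value is 70000 nM, with an expected range from 35000 nM to 130000 nM.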

Compound 4, half-maximal cytotoxic concentration: 115000 nM
Beside the measured number, compound 4's estimate is 1.6-fold (0.22 log units) below it; the range from low to high includes it.
By their numbers in this assay, from the lowest: compounds 3, 2 and 4 (each within the scatter of the next). At a limit, above all of these: compound 1.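

In this assay, exchanging 3-fluorophenyl for 4-fluorophenyl on the amide-type nitrogen gives a 1.8-fold higher number from compound 3 to compound 4 (0.25 log units; within the scatter), so within this pair, where the fluoro group sits on the aromatic ring makes no difference that can be told from the scatter. Against the compound without fluoro, the same exchange of hydrogen gives a 1.1-fold higher number from compound 2 to compound 4 (0.04 log units; within the scatter), and so neither fluorophenyl group has yet separated from compound 2 in this test. Nothing shown here gives a cause for these small steps.

From the compounds shown here alone, whether a group other than fluoro on that aromatic ring, such as a methoxy group, an amine or a carboxylic acid, would take the number beyond the scatter stays open. So does the effect of a longer chain on the amide-type nitrogen in place of the aromatic ring.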